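Fluoro in Place of Chloro: From Compound 2 to Compound 4

The compounds below may be only part of what the source reports. "The series", "measured", "known", "first", "only" and "open" are said of these compounds alone.

Of the compounds shown here, three have so far been tested in a functional assay on MCF7 cells (Homo sapiens) for antiproliferative activity, read by MTT assay, with a stated time of 72 h; on this read-out lower numbers stand for stronger inhibition and higher numbers for weaker inhibition. Compound 1 `CCN(CC)CCNc1cc(C)c2cc(NC(=O)c3ccc(Cl)c(Cl)c3)ccc2n1` gives 1420 nM. Compound 2 `CCN1CCN(c2cc(C)c3cc(NC(=O)c4ccc(Cl)cc4)ccc3n2)CC1` gives 1530 nM, the second highest of the three numbers and within the scatter of compound 1; compound 3 `Cc1cc(N(C)C)nc2ccc(NC(=O)c3ccc(Cl)c(Cl)c3)cc12` gives 33300 nM and lies furthest away. Going by the values given here, the only single-point step known is a 23-fold higher number from compound 1 to compound 3 (1.37 log units; beyond the scatter), and it concerns the dimethylamino and (2-(diethylamino)ethyl)amino groups, not the halogen examined here. Compound 4 `CCN1CCN(c2cc(C)c3cc(NC(=O)c4ccc(F)cc4)ccc3n2)CC1` differs from compound 2 by fluoro in place of chloro on an aromatic carbon. Among the compounds with values here, no measured step bears on this exchange, so only a small shift, expected to stay within the scatter, is estimated as a 1.6-fold higher number from compound 2 to compound 4 (0.21 log units; within the scatter). Compound 4 is therefore expected to give 2500 nM, within a range from 900 nM to 7000 nM.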

Compound 4, half-maximal inhibitory concentration: 4030 nM
For compound 4 the middle estimate is 1.6-fold (0.21 log units) below the measured one, and the stated range covers the measured number.
By their numbers in this assay, from the lowest: compounds 1 and 2 (each within the scatter of the next); then compound 4; then compound 3.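

In this assay the halogen on the 4-chlorophenyl group makes a measurable difference: fluoro in place of chloro gives a 2.6-fold higher number from compound 2 to compound 4 (0.42 log units; beyond the scatter), a modest step but one beyond the scatter. Going by these compounds alone, the only earlier single-place step concerned the amine groups, so this is the first reading on the (4-chlorophenyl)carbonyl side of the molecule. Nothing available explains this step. From the compounds shown here alone, whether bromo, methoxy or plain hydrogen in the same place would raise or lower the number remains open, as does whether this exchange would act alike with another amine on the shared core.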